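The compounds below may be only part of what the source reports. "The series", "measured", "known", "first", "only" and "open" are said of these compounds alone.

Measured in a functional assay on MCF7 cells (Homo sapiens) for antiproliferative activity, read by MTT assay, with a stated time of 48 h (on this read-out higher numbers stand for weaker inhibition and lower numbers for stronger inhibition), so far:
compound 1 `COc1cc(C2=N/C(=C\c3cc(Br)cc(Br)c3OC(C)=O)C(=O)NN2C(N)=S)cc(OC)c1OC` gives 360 nM
compound 2 `COc1cc(C2=N/C(=C\c3cc(Br)cc(Br)c3OC(C)=O)C(=O)NN2c2ncc(-c3ccc(Br)cc3)s2)cc(OC)c1OC` gives 3160 nM
compound 3 `COc1ccc(C2=N/C(=C\c3cc(Br)cc(Br)c3OC(C)=O)C(=O)NN2c2ccccc2)cc1OC` gives 5390 nM

Compound 3 at 5390 nM lies within the scatter of compound 2 and beyond the scatter of compound 1. Compound 4 `COc1cc(C2=N/C(=C\c3cc(Br)cc(Br)c3OC(C)=O)C(=O)NN2c2ccccc2)cc(OC)c1OC` differs from compound 3 by methoxy in place of hydrogen on an aromatic carbon and so goes from 3,4-dimethoxyphenyl to 3,4,5-trimethoxyphenyl, with methoxy in place of hydrogen on an aromatic carbon.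

Going by the values given here, no measured step covers this change. Among the compounds with values here, the only measured step of an 8.8-fold higher number from compound 1 to compound 2 (0.94 log units; beyond the scatter) is a change on an amine nitrogen in a ring, a different place, and it bears on the methoxy only indirectly. Compound 1 and compound 2 both carry the 3,4,5-trimethoxyphenyl group and still differ by that step, so the group alone does not set the number. Compound 4 keeps the group of compound 3 on that ring nitrogen, and in this assay no shift beyond the scatter is expected. The expected step of a 1.3-fold lower number from compound 3 to compound 4 (0.13 log units; within the scatter) is a small one. Compound 4 is estimated at 4000 nM with an expected range from 1500 nM to 10000 nM for the measurement.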

Compound 4, half-maximal inhibitory concentration: 350 nM
Beside the measured number, compound 4's estimate is 11-fold (1.06 log units) above it; the whole stated range lies above it.
By their numbers in this assay, from the lowest: compounds 4 and 1 (each within the scatter of the next); then compounds 2 and 3 (each within the scatter of the next).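

In this assay, going by these compounds alone, adding methoxy on the aromatic carbon, 3,4-dimethoxyphenyl to 3,4,5-trimethoxyphenyl, with phenyl held on the ring nitrogen, gives a large step: a 15-fold lower number from compound 3 to compound 4 (1.19 log units; beyond the scatter), the first reading of this position. With 3,4,5-trimethoxyphenyl held fixed, the ring nitrogen group also counts: a 9.0-fold lower number from compound 2 to compound 4 (0.96 log units; beyond the scatter), whereas a 1.0-fold lower number from compound 1 to compound 4 (0.01 log units; within the scatter), so phenyl and the group of compound 1 cannot be told apart here, and the larger group of compound 2 stands apart from both. No measurement at hand accounts for the methoxy step.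

Going by these compounds, it remains open whether methoxy itself is needed on that aromatic carbon, or whether an ethoxy, a hydroxyl or a chlorine there would give a similar step. Also open, on these data alone, is whether the step carries over when the groups of compound 1 or compound 2 sit on the ring nitrogen.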